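Bromo for methoxy on the styryl ring in DU-145 growth

This account rests on a few compounds, and the source may have more. Where it says the series, first, only, none or still open, it means among the compounds named here.

Measured compounds:
compound 1 `CN(C)c1ccc(/C=C(/Sc2ccc(Br)cc2)C(=O)c2ccc(Cl)cc2)cc1`: > 100000 nM
compound 2 `O=C(/C(=C\c1ccc(Br)cc1)SCc1ccc(Cl)cc1)c1ccc(Cl)cc1`: 1000 nM
compound 3 `COc1ccc(/C=C(/Sc2ccc(Br)cc2)C(=O)c2ccc(Cl)cc2)cc1`: 50000 nM

In a functional assay on DU-145 cells (Homo sapiens) for inhibition, read by trypan blue exclusion, with a stated time of 96 h (on this read-out lower numbers stand for stronger inhibition of growth and higher numbers for weaker inhibition of growth), compound 1 reaches only the limit (the limit of > 100000 nM in this assay, at which 1 of the 3 values shown sits). Compound 3 `COc1ccc(/C=C(/Sc2ccc(Br)cc2)C(=O)c2ccc(Cl)cc2)cc1` stands highest of the two numbers given; compound 2 gives 1000 nM, a lower number by a wide margin. Within the data shown here, the only measured step, an at least 2.0-fold lower number from compound 1 to compound 3 (0.30 log units; that floor lies within the scatter), is a floor and does not concern the change now followed. Compound 4 `O=C(/C(=C\c1ccc(Br)cc1)Sc1ccc(Br)cc1)c1ccc(Cl)cc1` differs from compound 3 by bromo in place of methoxy on an aromatic carbon. Nothing measured covers methoxy to bromo at this place, yet compound 2 carries the same 4-bromophenyl and gives 1000 nM, so a lower number is expected for compound 4, of the size a 17-fold lower number from compound 3 to compound 4 (1.22 log units; beyond the scatter). Compound 4 is estimated at 3000 nM, between 500 nM and 20000 nM.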

Compound 4, concentration for 50% growth inhibition: 1000 nM
For compound 4 the middle estimate is 3.0-fold (0.48 log units) above the measured one; the range from low to high includes it.
By their numbers in this assay, from the lowest: compounds 2 and 4 (each within the scatter of the next); then compound 3. At a limit, above all of these: compound 1.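

In this assay, bromo in place of methoxy on an aromatic carbon gives a 50-fold lower number from compound 3 to compound 4 (1.70 log units; beyond the scatter), so this position responds strongly to the change from 4-methoxyphenyl to 4-bromophenyl. On the sulfur, 4-bromophenyl in place of 4-chlorobenzyl gives no change at the digits printed from compound 2 to compound 4 (within the scatter), so that exchange shows no separable effect with bromo on the styryl ring. The step of an at least 100-fold lower number from compound 1 to compound 4 (2.00 log units; beyond the scatter) is only a floor, since compound 1 stands at a limit: the limit of > 100000 nM in this assay, at which 1 of the 4 values shown sits.

Going by these compounds, whether fluoro, a nitrile or a carboxylic acid at this position would match bromo remains open. So does whether methoxy would cost as much alongside 4-chlorobenzyl on the sulfur.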